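The source may hold more compounds than are shown below. What is called first, only, known or untested is meant among the compounds shown, and "the series" means these compounds.

Among the compounds with values here, compound 1, `Nc1scc(CN2CCN(c3ccc(Cl)cc3F)CC2)c1C(=O)c1ccc(Cl)cc1`, is one of two compounds measured in a functional assay on CHO cells with adenosine receptor A1 (Homo sapiens) as the target, read by cAMP accumulation and immunoassay, with a stated time of 6 min, tested at 0.01 uM; on this read-out higher numbers stand for a weaker effect at the one concentration tested and lower numbers for a stronger effect. In this assay compound 1 gives -9.2%, and compound 2, `Nc1scc(CN2CCN(c3ccc([N+](=O)[O-])cc3)CC2)c1C(=O)c1ccc(Cl)cc1`, gives -12%; the step of a number 2.8 percentage points lower from compound 1 to compound 2 (within the scatter) stays within the scatter, so the two numbers stand together rather than apart. Compound 3, `Nc1scc(CN2CCN(c3ccc(F)cc3F)CC2)c1C(=O)c1ccc(Cl)cc1`, has not yet been measured. It differs from compound 1 in one place: fluoro in place of chloro on an aromatic carbon. Within the data shown here, the one measured step bears on this only loosely, since it exchanges the whole aryl group on the amine nitrogen in the ring, yet even that larger exchange produced a number 2.8 percentage points lower from compound 1 to compound 2 (within the scatter) and nothing beyond the scatter. The smaller exchange of a single halogen is therefore expected to leave the read-out essentially where compound 1 stands, with a step of a number 0.2 percentage points higher from compound 1 to compound 3 (within the scatter) expected. For compound 3 the estimate in this assay is -9%, between -22% and 4%.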

Compound 3, a percentage reported as activity, at one concentration (the size of the read-out at that concentration, not a potency): 0%
Estimate against measurement, compound 3: 9 percentage points below; the measured number falls inside the stated range.
By their numbers in this assay, from the lowest: compounds 2, 1 and 3 (each within the scatter of the next, the first and the last beyond it).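

In this assay, fluoro in place of chloro on the aromatic carbon para to a large group gives a number 9.2 percentage points higher from compound 1 to compound 3 (within the scatter), so at this position, which the earlier pair did not vary, one halogen can replace the other without a step beyond the scatter. The 2,4-difluorophenyl group in place of 4-nitrophenyl gives a number 12 percentage points higher from compound 2 to compound 3 (beyond the scatter), the only step beyond the scatter among these compounds, although compound 1 lies within the scatter of both compound 2 and compound 3, so the three do not divide into separate groups. No available evidence accounts for either step.

The compounds shown leave open whether a methoxy group, an amine or a carboxylic acid at this position would stay within the scatter of compound 1. From the compounds shown here alone, each number comes from one concentration, and how the compounds rank in potency stays open.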